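From piperidin-1-yl to phenyl on a sulfonyl sulfur

The compounds below may be only part of what the source reports. "The series", "measured", "known", "first", "only" and "open" are said of these compounds alone.

Three amides have been measured in a functional assay on A2780 cells (Homo sapiens) for inhibition, read by sulforhodamine B assay, with a stated time of 72 h; on this read-out lower numbers stand for stronger inhibition and higher numbers for weaker inhibition. Compound 1 (`O=C(NCc1ccc(S(=O)(=O)N2CCCCC2)cc1)c1cc2ccncc2[nH]1`) gives 1700 nM. For the measured compounds named here, compound 2 (`O=C(NCc1ccc(S(=O)(=O)N2CCCCC2)cc1)c1cnc2nccn2c1`) gives 130 nM, the lowest number so far. Compound 3 (`O=C(NCc1ccc(S(=O)(=O)N2CCCCC2)cc1)c1cc2cccnc2s1`) gives > 10000 nM, which is a limit of the assay and not a number.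

Compound 4 (`O=C(NCc1ccc(S(=O)(=O)c2ccccc2)cc1)c1cnc2nccn2c1`) keeps the group on the carbonyl carbon of compound 2 but has phenyl in place of piperidin-1-yl on a sulfonyl sulfur.

Going by the values given here, all the measured steps change the group on the carbonyl carbon, and two are large: a 13-fold lower number from compound 1 to compound 2 (1.12 log units; beyond the scatter) and an at least 76-fold higher number from compound 2 to compound 3 (1.88 log units; beyond the scatter). Among the compounds with values here, none changes the group on the sulfonyl sulfur, so they show only that one change can move the number a long way, not which way this change will go. Starting from compound 2 at 130 nM, a moderate move towards stronger inhibition is expected, though with wide uncertainty. The expected step is a 3.3-fold lower number from compound 2 to compound 4 (0.51 log units; beyond the scatter). For compound 4 the estimated value is 40 nM, with an expected range of 6 nM to 250 nM.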

Compound 4, half-maximal inhibitory concentration: 68 nM
The estimate for compound 4 lay 1.7-fold (0.23 log units) below the measured number, within the range that was stated.
By their numbers in this assay, from the lowest: compounds 4 and 2 (each within the scatter of the next); then compound 1. At a limit, above all of these: compound 3.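

For the compounds shown here, this is the first step at the sulfonyl sulfur, since every earlier step changed the group on the carbonyl carbon. Putting phenyl in place of piperidin-1-yl gives a 1.9-fold lower number from compound 2 to compound 4 (0.28 log units; within the scatter) in this assay, so here the assay does not separate the two groups. With the group on the carbonyl carbon of compound 2, a six-membered non-aromatic ring with one nitrogen and a six-membered aromatic ring of carbon only therefore serve equally well at this position, and nothing shown gives a reason for this.

From the compounds shown here alone, it remains open whether the same swap would leave the number unchanged with the carbonyl groups of compound 1 or compound 3. Also open, going by these compounds, is how a dimethylamino group, a morpholine or a phenyl carrying a carboxylic acid would read on the same sulfur.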